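A Fluoro-for-Hydroxy Swap on Two Weak Inhibitors

A few compounds are considered here, and "the series" means these few. Any claim that something is new, unique, unknown or untested is made for them only; others in the source may bear on it.

Of the compounds shown here, two have so far been measured in a functional assay on cells (T-cell, Mus musculus, strain BALB/c) for inhibition, read by MTT assay, with a stated time of 72 h; on this read-out lower numbers stand for stronger inhibition and higher numbers for weaker inhibition. Compound 1 `C=C(CCc1cc(O)c2c(=O)cc(-c3ccccc3)oc2c1)Cc1c(Br)cccc1C(=O)CC` gives 40700 nM there. Compound 2 `COC(=O)c1cc(O)ccc1OC(=O)COc1cc(O)c2c(=O)cc(-c3ccccc3)oc2c1` gives 29500 nM in this assay, the lower of the two numbers, although its gap to compound 1 lies within the scatter, so the two cannot be ranked against each other. Compound 3 `COC(=O)c1cc(F)ccc1OC(=O)COc1cc(O)c2c(=O)cc(-c3ccccc3)oc2c1` has not yet been measured. It differs from compound 2 by fluoro in place of hydroxy on an aromatic carbon. Within the data shown here, no step between measured compounds is available to show what such a change does to the read-out, so the expectation rests on compound 2 alone. Given that compound 2 gives 29500 nM, compound 3 is expected to stay close to it, with a step of a 1.2-fold higher number from compound 2 to compound 3 (0.07 log units; within the scatter) that is not expected to reach beyond the scatter. Compound 3 is accordingly estimated at 35000 nM, within a range from 12000 nM to 100000 nM.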

Compound 3, half-maximal inhibitory concentration: 6820 nM
Compound 3: middle estimate off by 5.1-fold (0.71 log units), on the high side, and the stated range ends above it.
By their numbers in this assay, from the lowest: compound 3; then compounds 2 and 1 (each within the scatter of the next).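

At this aromatic carbon, para to a large group and meta to a methoxycarbonyl group, fluoro in place of hydroxy gives a 4.3-fold lower number from compound 2 to compound 3 (0.64 log units; beyond the scatter) in this assay. Among these compounds, this is the first step here beyond the scatter, and it shows that the read-out responds to what sits at this position, which compounds 1 and 2 could not show. The change also takes away a hydrogen-bond donor and a hydrogen-bond acceptor, but this single step cannot separate that loss from the arrival of fluoro, and nothing measured here bears on why the number moves.

Going by these compounds, what a plain hydrogen, chloro, methoxy or an amine would do at this carbon stays open. So does whether replacing the hydroxy on the shared core with fluoro would move the number in the same way.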